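The source may hold more compounds than are shown below. What is called first, only, known or untested is meant among the compounds shown, and "the series" means these compounds.

Measured so far in a functional assay on the whole organism for inhibition, with Mus musculus as the target, at a dose of 32 mg/kg by the oral route; a higher number here means more inhibition at the dose given (going by the name of the read-out), a lower number less inhibition:

compound 1 `CSc1ccc2c(c1)c(O)c(C(=O)N(C)c1ccccc1)c(=O)n2C`: 100%
compound 2 `CN(C(=O)c1c(O)c2cc(Oc3ccccc3)ccc2n(C)c1=O)c1ccccc1`: 26%
compound 3 `CNc1c(C(=O)N(C)c2ccccc2)c(=O)n(C)c2ccc(SC)cc12`: 83%

Compound 3 stands second highest of the three, set off from compound 1 by a number 17 percentage points lower from compound 1 to compound 3 (beyond the scatter) and far ahead of compound 2, whose low number comes from a number 74 percentage points lower from compound 1 to compound 2 (beyond the scatter). The next compound, compound 4 `CSc1ccc2c(c1)c(S)c(C(=O)N(C)c1ccccc1)c(=O)n2C`, is not yet measured. It differs from compound 3 in one place: sulfanyl in place of methylamino on an aromatic carbon, on an aromatic carbon of the shared core, ortho to a fused ring and ortho to a large group.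

For the measured compounds named here, only one measured step touches this position: a number 17 percentage points lower from compound 1 to compound 3 (beyond the scatter), a modest lowering when methylamino replaced hydroxy. Going by the values given here, no measured pair shows sulfanyl anywhere. Both hydroxy and methylamino gave high numbers here, and sulfanyl is counted as the same pattern. A small movement in either direction is therefore expected, most likely not beyond the scatter: the expected step is a number 2 percentage points higher from compound 3 to compound 4 (within the scatter). For compound 4 the estimate in this assay is 85%, with a range from 55% to 100%.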

Compound 4, a percentage reported as inhibition, in the whole organism at one dose (the size of the read-out at that dose, not a potency): 19%
Compound 4: the middle estimate sits 66 percentage points above what was measured; measured number outside the range, below it.
By their numbers in this assay, from the lowest: compounds 4 and 2 (each within the scatter of the next); then compound 3; then compound 1.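

In this assay this position proves far more selective than the hydroxy and methylamino compounds suggested: sulfanyl in place of methylamino gives a number 64 percentage points lower from compound 3 to compound 4 (beyond the scatter) in the read-out, and sulfanyl in place of hydroxy gives a number 81 percentage points lower from compound 1 to compound 4 (beyond the scatter) on the same core. Methylamino and sulfanyl have the same hydrogen-bond donor and acceptor counts and no net charge, so those counts alone do not set the number at this position. Nothing at hand accounts for the drop.

From the compounds shown here alone, whether a methoxy group or a primary amine at this position would stay with hydroxy and methylamino or fall with sulfanyl remains open. Also open, going by these compounds, is whether sulfanyl would give a step of similar size with phenoxy in place of methylsulfanyl on the core.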